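From Cyclohexyl to Pentyl Ester: Expected Cytotoxicity

The source may report more compounds than this note shows. Statements on the series, on what has been measured and on what is new or still open speak of the compounds shown alone.

Compound 1 `Nc1ncnc2c1ncn2CC(O)C(=O)OCCO`: in a functional assay on HeLa cells (Homo sapiens) for cytotoxicity (on this read-out higher numbers stand for lower toxicity in this test and lower numbers for higher toxicity in this test), compound 1 gives > 400 ug/mL, a limit of the assay.
Compound 2 `COC(=O)C(O)Cn1cnc2c(N)ncnc21`: in this assay compound 2 gives > 400 ug/mL, also a limit.
Compound 3 `Nc1ncnc2c1ncn2CC(O)C(=O)OC1CCCCC1`: in this assay compound 3 gives 100 ug/mL.

Compound 3 thus stands as the only true number shown; the other two values sit at the limit of > 400 ug/mL in this assay, at which 2 of the 3 values shown sit. Compound 4 `CCCCCOC(=O)C(O)Cn1cnc2c(N)ncnc21` differs from compound 3 in one place: pentyl in place of cyclohexyl on an oxygen next to a carbonyl group. For the measured compounds named here, the steps that bear on this change are an at least 4.0-fold lower number from compound 1 to compound 3 (0.60 log units; beyond the scatter) and an at least 4.0-fold lower number from compound 2 to compound 3 (0.60 log units; beyond the scatter), both at least modest falls when cyclohexyl entered on the ester oxygen. Pentyl, like cyclohexyl, carries no hydrogen-bond donor or acceptor, so in this assay no step beyond the scatter is expected. Compound 4 is therefore estimated at 150 ug/mL (range 50 ug/mL to 400 ug/mL), an expected step of a 1.5-fold higher number from compound 3 to compound 4 (0.18 log units; within the scatter).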

Compound 4, minimum cytotoxic concentration: > 400 ug/mL
Compound 4 gave a limit, no number (the forecaster's own chance of this, stated with the estimate: 25%); middle value at least 2.6-fold (0.42 log units) away from the limit.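

At the ester oxygen, the ring counts for more than the carbon count suggests: in this assay the swap of cyclohexyl for pentyl, a chain with no ring, brings an at least 4.0-fold higher number from compound 3 to compound 4 (0.60 log units; beyond the scatter). The value of compound 4 is a limit, so the steps to it from compound 1 and compound 2 cannot be read. Of the ester groups shown, only cyclohexyl gives a true number, and the others share one limit: the limit of > 400 ug/mL in this assay, at which 3 of the 4 values shown sit.

Going by these compounds, whether a longer chain such as octyl would lower the number as cyclohexyl does stays open. So does the effect of a smaller ring such as cyclopentyl.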